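A few compounds are considered here, and "the series" means these few. Any claim that something is new, unique, unknown or untested is made for them only; others in the source may bear on it.

In an assay on isolated protein for inhibition of thiosulfate sulfurtransferase (Homo sapiens), with a stated time of 60 min, in the absence of a further agent (on this read-out higher numbers stand for weaker inhibition and lower numbers for stronger inhibition), compound 2 `O=C(Nc1ccc(Sc2nc3ccccc3s2)cc1)c1cc(Br)ccc1O` gives > 100000 nM, which is a limit of the assay rather than a number. Compound 1 `O=C(Nc1ccc(Sc2nc3ccccc3s2)cc1)c1cc(Br)cc(Br)c1O` gives > 100000 nM in this assay, also a limit. Both values sit at the limit of > 100000 nM in this assay, at which 2 of the 2 values shown sit, so the step between them, a step that the two limits leave unreadable from compound 1 to compound 2, cannot be read from these two limits. Compound 3 `COc1ccccc1C(=O)Nc1ccc(Sc2nc3ccccc3s2)cc1` has not yet been measured in this assay; it differs from compound 2 by 2-methoxyphenyl in place of 5-bromo-2-hydroxyphenyl on a carbonyl carbon. Among the measured compounds shown here, no measured step bears on this change, because the single step known, a step that the two limits leave unreadable from compound 1 to compound 2, is unreadable, and compound 2 itself stands at the limit, so neither direction nor size can be anticipated from what is known. Compound 3 is expected to remain at the limit of this assay. The estimated step is a number no higher from compound 2 to compound 3 (the limit leaves the size open). The estimate for compound 3 is 100000 nM, with a range from 30000 nM to 300000 nM.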

Compound 3, half-maximal inhibitory concentration: > 100000 nM
Compound 3: no number, only a limit; the forecaster's own chance of this, stated with the estimate: 85%; the middle value sits exactly at the limit.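

In this assay, among the compounds shown here, compound 3 gives > 100000 nM, a limit rather than a number, and no step from compound 1 or compound 2 to compound 3 can be read: the limit of > 100000 nM in this assay, at which 3 of the 3 values shown sit. The compounds shown leave open whether changing the group on the carbonyl carbon affects inhibition at all.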